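Replacing the hydroxyphenoxy chain in a melanocortin receptor 4 series

A few compounds are considered here, and "the series" means these few. Any claim that something is new, unique, unknown or untested is made for them only; others in the source may bear on it.

Measured compounds:
compound 1 `CC(C)C[C@H](N)c1cc(C(F)(F)F)ccc1N1CCN(C(=O)COc2ccc3ccccc3c2)CC1` — 2000 nM
compound 2 `CC(C)C[C@H](N)c1cc(C(F)(F)F)ccc1N1CCN(C(=O)CC(C)C(=O)c2ccc(Cl)cc2)CC1` — 1100 nM
compound 3 `CC(C)C[C@H](N)c1cc(C(F)(F)F)ccc1N1CCN(C(=O)COc2ccc(O)cc2)CC1` — 4600 nM

The three compounds share one core and differ only in the group on the carbonyl carbon attached to the ring nitrogen. In an assay on HEK293 cells for displacement of a labelled ligand from Melanocortin receptor 4 (Homo sapiens) (a higher number here means a weaker inhibitor, a lower number a stronger inhibitor), compound 3 gives 4600 nM, the highest number of the three; its nearest neighbour is compound 1, and the step of a 2.3-fold higher number from compound 1 to compound 3 (0.36 log units; beyond the scatter) lies beyond the scatter, as does a 4.2-fold higher number from compound 2 to compound 3 (0.62 log units; beyond the scatter). The step of a 1.8-fold lower number from compound 1 to compound 2 (0.26 log units; within the scatter) stays within the scatter.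

Compound 4 `CCOc1cccc(CC(C)C(=O)N2CCN(c3ccc(C(F)(F)F)cc3[C@@H](N)CC(C)C)CC2)c1` has not yet been measured. It differs from compound 3 in one place:
1-(3-ethoxybenzyl)ethyl in place of (4-hydroxyphenoxy)methyl on a carbonyl carbon

The step that bears most on this change is a 4.2-fold higher number from compound 2 to compound 3 (0.62 log units; beyond the scatter), since compound 2 also carries a branched carbon chain on that carbonyl carbon rather than an oxygen-linked ring; reading it in reverse suggests a lower number. The step of a 2.3-fold higher number from compound 1 to compound 3 (0.36 log units; beyond the scatter) points the same way, though smaller. Compound 4 is therefore expected to show a decrease, a 3.5-fold lower number from compound 3 to compound 4 (0.55 log units; beyond the scatter), landing near the values of compound 1 and compound 2 rather than below them. The estimate for compound 4 is 1300 nM, with a range from 450 nM to 3800 nM.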

Compound 4, inhibition constant: 2200 nM
The estimate for compound 4 lay 1.7-fold (0.23 log units) below the measured number; the measured number falls inside the stated range.
By their numbers in this assay, from the lowest: compounds 2, 1 and 4 (each within the scatter of the next); then compound 3.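

In this assay, 1-(3-ethoxybenzyl)ethyl in place of (4-hydroxyphenoxy)methyl on the carbonyl carbon gives a 2.1-fold lower number from compound 3 to compound 4 (0.32 log units; beyond the scatter), a second group without the hydroxy substituent that stands apart from compound 3. Against the other two groups the new one shows a 2.0-fold higher number from compound 2 to compound 4 (0.30 log units; within the scatter) and a 1.1-fold higher number from compound 1 to compound 4 (0.04 log units; within the scatter), so this position tolerates three quite differently built groups that the assay cannot separate, and among the four compounds only compound 3 stands apart. Nothing available here accounts for that separation.

The compounds shown leave open whether the hydroxy group of compound 3 alone sets it apart, as the step to compound 4 changes the linking chain and the ring substituent together. They also leave open whether an amine or a carboxylic acid on the aromatic ring would shift the number.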